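Chloro for methyl on the piperazine aryl: expected effect

The compounds below may be only part of what the source reports. "The series", "measured", "known", "first", "only" and "open" are said of these compounds alone.

Measured so far:
compound 1 `O=C(CN1CCN(c2ccccc2)CC1)N(c1ccccc1)c1ccccc1` — 27 mg/kg
compound 2 `Cc1ccc(N2CCN(CC(=O)N(c3ccccc3)c3ccccc3)CC2)cc1` — 31.2 mg/kg
compound 3 `O=C(CN1CCN(c2cccc(C(F)(F)F)c2)CC1)N(c1ccccc1)c1ccccc1` — 30 mg/kg

All three were tested in a functional assay on the whole organism (strain Swiss albino) for inhibition, with Mus musculus as the target, with stated times of 30 min, 10 min and 20 min; on this read-out higher numbers stand for an effect only at larger amounts of compound and lower numbers for an effect already at smaller amounts. Compound 2 stands with the other two: a 1.2-fold higher number from compound 1 to compound 2 (0.06 log units; within the scatter), and a 1.0-fold lower number from compound 2 to compound 3 (0.02 log units; within the scatter), each of these within the scatter, as is a 1.1-fold higher number from compound 1 to compound 3 (0.05 log units; within the scatter). Among the measured compounds shown here, nothing among the measured numbers separates the three compounds.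

Compound 4 `O=C(CN1CCN(c2cccc(Cl)c2)CC1)N(c1ccccc1)c1ccccc1` has not yet been measured in this assay. It differs from compound 2 by 3-chlorophenyl in place of 4-methylphenyl on an amine nitrogen in a ring. The step that bears most directly on this change is a 1.0-fold lower number from compound 2 to compound 3 (0.02 log units; within the scatter), which exchanged one aryl group on that ring nitrogen for another of the same kind, and a 1.1-fold higher number from compound 1 to compound 3 (0.05 log units; within the scatter) shows that adding a group to that aryl ring also left the number within the scatter. For the measured compounds named here, nothing measured so far points in either direction, so no step beyond the scatter is expected from compound 2 to compound 4.

Compound 4 is therefore estimated at 30 mg/kg, with a range of 17 mg/kg to 55 mg/kg. The expected step is a 1.0-fold lower number from compound 2 to compound 4 (0.02 log units; within the scatter).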

Compound 4, dose for half-maximal effect: 18 mg/kg
Estimate against measurement, compound 4: 1.7-fold (0.22 log units) above, and the stated range covers the measured number.
By their numbers in this assay, from the lowest: compounds 4, 1, 3 and 2 (each within the scatter of the next).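

In this assay the exchange of 4-methylphenyl for 3-chlorophenyl on the amine nitrogen in a ring gives a 1.7-fold lower number from compound 2 to compound 4 (0.24 log units; within the scatter) and so remains unresolved from no change, even though it is the largest step yet seen at this place. The same holds for a 1.7-fold lower number from compound 3 to compound 4 (0.22 log units; within the scatter) and for a 1.5-fold lower number from compound 1 to compound 4 (0.18 log units; within the scatter), so a chloro group joins methyl and trifluoromethyl among the aryl substituents that do not separate from the unsubstituted phenyl of compound 1. Nothing shown here explains where compound 4 falls.

On these data alone, it remains open whether an amine or a carboxylic acid on this aryl ring would give a step beyond the scatter. Also open, as far as these compounds go, is whether a longer chain linking the carbonyl to the ring nitrogen would do so.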